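The compounds below may be only part of what the source reports. "The series", "measured", "known", "first", "only" and "open" are said of these compounds alone.

Measured compounds:
Compound 1, `COc1ccc(-c2cn3ccnc3c(-c3ccc4ncn(C5CCCCC5)c4c3)n2)cc1`: 92.5%
Compound 2, `Brc1ccc(-c2cn3ccnc3c(-c3ccc4ncn(C5CCCCC5)c4c3)n2)cc1`: 41.3%

In a functional assay on SF-295 cells (Homo sapiens) for inhibition, read by sulforhodamine B assay, with a stated time of 48 h, tested at 10 uM (a higher number here means more inhibition at the concentration tested (going by the name of the read-out), a lower number less inhibition), compound 2 stands lowest of the two; its nearest neighbour, compound 1, lies higher by a number 51.2 percentage points lower from compound 1 to compound 2 (beyond the scatter) read in reverse. The unmeasured compound 3, `Fc1ccccc1-c1cn2ccnc2c(-c2ccc3ncn(C4CCCCC4)c3c2)n1`, differs from compound 2 by 2-fluorophenyl in place of 4-bromophenyl on an aromatic carbon. Among the compounds with values here, no measured step swaps one halogen for another, so only the step from compound 1 to compound 2, which was a number 51.2 percentage points lower from compound 1 to compound 2 (beyond the scatter), shows that a change at this ring can move the number far. For compound 3 a modest rise is expected, a number 13.7 percentage points higher from compound 2 to compound 3 (beyond the scatter), with wide uncertainty. Compound 3 is estimated at 55%, between 20% and 90%.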

Compound 3, a percentage reported as inhibition, at one concentration (the size of the read-out at that concentration, not a potency): 10.4%
For compound 3 the middle estimate is 44.6 percentage points above the measured one, and the stated range ends above it.
By their numbers in this assay, from the lowest: compound 3; then compound 2; then compound 1.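

In this assay, this position separates even two halogen-bearing phenyl groups, with a number 30.9 percentage points lower from compound 2 to compound 3 (beyond the scatter). The overall span across the three groups is wider still, with a number 82.1 percentage points lower from compound 1 to compound 3 (beyond the scatter). This swap alters the halogen and its place on the phenyl ring together, and the two effects cannot be told apart here. Nothing available explains the drop. Going by these compounds, a 4-fluorophenyl group would help separate halogen from placement, while the response to a phenyl ring carrying an amine remains open.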